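This account rests on a few compounds, and the source may have more. Where it says the series, first, only, none or still open, it means among the compounds named here.

The measured compounds and their values in a functional assay on HeLa cells (Homo sapiens) for inhibition, with a stated time of 72 h; on this read-out lower numbers stand for an effect already at smaller amounts and higher numbers for an effect only at larger amounts of compound:

compound 1, `COc1cc(OCc2ccc(Cl)cc2)ccc1CNCc1ccncc1`, this assay 440 nM
compound 2, `COc1cc(CNCc2ccncc2)ccc1OCc1ccc(Cl)nc1`, this assay 400 nM
compound 3, `COc1cc(CNCc2ccncc2)ccc1OCc1ccc(Cl)cc1`, this assay 890 nM

Compound 1 and compound 3 are built from the same atoms joined differently; the difference between the two cores is not broken down here. Compound 1 and compound 2 lie within the scatter of each other, whereas compound 3 sits beyond the scatter from both.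

One structural change is shown twice. From compound 3 to compound 2 it reads (6-chloropyridin-3-yl in place of 4-chlorophenyl on a saturated chain carbon bound to an oxygen on an aromatic ring), and it gave a 2.2-fold lower number from compound 3 to compound 2 (0.35 log units; beyond the scatter). The same change, (6-chloropyridin-3-yl in place of 4-chlorophenyl on a saturated chain carbon bound to an oxygen on an aromatic ring), leads from compound 1 to the unmeasured compound 4, `COc1cc(OCc2ccc(Cl)nc2)ccc1CNCc1ccncc1`; the place is identical in both cases, so it is the same change on a different core.

Because the measured instance, a 2.2-fold lower number from compound 3 to compound 2 (0.35 log units; beyond the scatter), was a modest step beyond the scatter, a step of similar size is expected from compound 1 to compound 4 in this assay, namely a 2.0-fold lower number from compound 1 to compound 4 (0.30 log units; within the scatter). This rests on a single measured pair, so the range is kept wide. Compound 4 is estimated at 220 nM in this assay, between 90 nM and 550 nM.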

Compound 4, half-maximal effective concentration: 3300 nM
Estimate against measurement, compound 4: 15-fold (1.18 log units) below, and the stated range ends below it.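

In this assay, putting 6-chloropyridin-3-yl in place of 4-chlorophenyl on the core of compound 1 gave a 7.5-fold higher number from compound 1 to compound 4 (0.88 log units; beyond the scatter). The same change had the opposite direction on the other core, so the step measured there did not carry over: the same change on two cores in this assay, a 2.2-fold lower number (0.35 log units; beyond the scatter) from compound 3 to compound 2 and a 7.5-fold higher number (0.88 log units; beyond the scatter) from compound 1 to compound 4, 17-fold (1.22 log units) apart, beyond the scatter of two such steps. For the compounds shown here, this shows that, in these two pairs, the outcome of the change depends on the core that carries it, but with only two pairs it does not show what in the cores is responsible, nor which direction the change would take on a further core.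

On these data alone, it remains open whether the opposite directions on the two cores are particular to 6-chloropyridin-3-yl or also appear with other groups at this place, such as a phenyl ring bearing a fluorine or a nitrile in place of the chlorine. Also open, as far as these compounds go, is how the two cores would respond if the secondary amine were replaced by an amide.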